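Phenyl for tert-butyl on the aromatic nitrogen: compound 4

This account rests on a few compounds, and the source may have more. Where it says the series, first, only, none or still open, it means among the compounds named here.

Among the measured compounds shown here, compound 3 `CC(C)(C)n1ncc(OCc2nnc(-c3ccccc3)o2)c(Cl)c1=O` carries the only number measured in a functional assay on the whole organism for inhibition, with Mythimna separata as the target, with a stated time of 5 days (a higher number here means that more compound is needed for the effect, a lower number that less compound is needed), where compound 3 gives 12.2 ug/mL. Compound 1 `CCCCn1ncc(OCc2nnc(-c3ccccc3)o2)c(Cl)c1=O` in this assay gives > 300 ug/mL, a limit of the assay. Compound 2 `CCn1ncc(OCc2nnc(-c3ccccc3)o2)c(Cl)c1=O` in this assay likewise gives > 300 ug/mL, also a limit. Both sit at the limit of > 300 ug/mL in this assay, at which 2 of the 3 values shown sit. Compound 4 `O=c1c(Cl)c(OCc2nnc(-c3ccccc3)o2)cnn1-c1ccccc1` differs from compound 3 by phenyl in place of tert-butyl on an aromatic nitrogen. For the measured compounds named here, the measured steps touching this position are an at least 24-fold lower number from compound 1 to compound 3 (1.39 log units; beyond the scatter) and an at least 24-fold lower number from compound 2 to compound 3 (1.39 log units; beyond the scatter), each from a straight chain to tert-butyl; phenyl is neither, and no measured pair shows an aromatic group there. The step is therefore expected to be small or modestly upward in this assay, a 2.5-fold higher number from compound 3 to compound 4 (0.39 log units; beyond the scatter). Compound 4 is estimated at 30 ug/mL, within 6 ug/mL to 300 ug/mL.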

Compound 4, half-maximal effective concentration: 91.5 ug/mL
Beside the measured number, compound 4's estimate is 3.1-fold (0.48 log units) below it; the measured number falls inside the stated range.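

In this assay an aromatic group on the aromatic nitrogen gives a measured number, and the series now has a readable comparison at this position: a 7.5-fold higher number from compound 3 to compound 4 (0.88 log units; beyond the scatter) puts phenyl behind tert-butyl. Phenyl still improves on both straight chains, with an at least 3.2-fold lower number from compound 2 to compound 4 (0.51 log units; beyond the scatter) and an at least 3.2-fold lower number from compound 1 to compound 4 (0.51 log units; beyond the scatter) as steps bounded on one side. Those two steps start from a limit of the assay, not from numbers: the limit of > 300 ug/mL in this assay, at which 2 of the 4 values shown sit.

On these data alone, whether cyclohexyl or isopropyl on this nitrogen lands nearer compound 3 or compound 4 stays open. So does the effect of a chloro group on the phenyl of compound 4.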